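The source may hold more compounds than are shown below. What is called first, only, known or untested is meant among the compounds shown, and "the series" means these compounds.

Measured compounds:
Compound 1, `Cc1ccc(CC(CNC(=O)C(C)(C)c2ccc(NS(C)(=O)=O)cc2)COC(=O)C(C)(C)C)cc1C`, gives 104 nM in a functional assay on CHO cells for antagonist activity at transient receptor potential cation channel subfamily V member 1 (Rattus norvegicus); on this read-out higher numbers stand for weaker inhibition and lower numbers for stronger inhibition.
Compound 2, `Cc1ccc(CC(CNC(=O)C2(c3ccc(NS(C)(=O)=O)cc3)CC2)COC(=O)C(C)(C)C)cc1C`, gives 197 nM in this assay.

Compound 1 holds the lower of the two numbers, yet compound 2 lies within the scatter of it, so no order between them is established. Compound 3, `COc1cc(C(C)(C)C(=O)NCC(COC(=O)C(C)(C)C)Cc2ccc(C)c(C)c2)ccc1NS(C)(=O)=O`, differs from compound 1 in one place: methoxy in place of hydrogen on an aromatic carbon. Among the compounds with values here, no step between measured compounds offers a guide for this change, so the expected step of a 1.2-fold lower number from compound 1 to compound 3 (0.06 log units; within the scatter) is small and is not expected to reach beyond the scatter in this assay. The estimate for compound 3 in this assay is 90 nM, ranging from 30 nM to 300 nM.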

Compound 3, inhibition constant: 133 nM
Compound 3: middle estimate off by 1.5-fold (0.17 log units), on the low side; the measured number falls inside the stated range.
By their numbers in this assay, from the lowest: compounds 1, 3 and 2 (each within the scatter of the next).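

Placing methoxy in place of hydrogen on the aromatic carbon ortho to the methanesulfonamido group gives a 1.3-fold higher number from compound 1 to compound 3 (0.11 log units; within the scatter) in this assay. This is the first change on that ring among these compounds, and this larger group at this position leaves the read-out within the scatter of compound 1. Nothing measured on these compounds offers an explanation for this result. Open, on these data alone, is whether a hydroxy group, a chlorine atom or an amine on this same carbon would also stay within the scatter. Also open, as far as these compounds go, is how methoxy at this position would read on the core of compound 2.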